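Catechol-imine triazolone series: aryl replacing cyclopropyl on the ring

The compounds below may be only part of what the source reports. "The series", "measured", "known", "first", "only" and "open" are said of these compounds alone.

Measured compounds in a physicochemical assay; a higher number here means a weaker inhibitor, a lower number a stronger inhibitor:
compound 1 `Cc1n[nH]c(=O)n1/N=C/c1ccc(O)c(O)c1`, 0.025 ug/mL
compound 2 `COc1ccc(Cc2n[nH]c(=O)n2/N=C/c2ccc(O)c(O)c2)cc1`, 0.05 ug/mL
compound 3 `O=c1[nH]nc(C2CC2)n1/N=C/c1ccc(O)c(O)c1`, 0.05 ug/mL

Compound 3 stands level with compound 2 at the digits shown, the two together at the high end of the three numbers; the step between them and compound 1 is a 2.0-fold higher number from compound 1 to compound 3 (0.30 log units; within the scatter), within the scatter. Compound 4 `O=c1[nH]nc(-c2ccccc2)n1/N=C/c1ccc(O)c(O)c1` differs from compound 3 by phenyl in place of cyclopropyl on an aromatic carbon. The step that bears on this place is a 2.0-fold higher number from compound 1 to compound 3 (0.30 log units; within the scatter), a change of group on the same aromatic carbon that stayed within the scatter; the other step, a 2.0-fold higher number from compound 1 to compound 2 (0.30 log units; within the scatter), lies elsewhere and also stayed within the scatter. No step beyond the scatter is therefore expected in this assay for compound 4, with a 1.2-fold higher number from compound 3 to compound 4 (0.08 log units; within the scatter) as the estimated shift. Compound 4 is expected to give 0.06 ug/mL, in the range 0.025 ug/mL to 0.15 ug/mL.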

Compound 4, half-maximal inhibitory concentration: 0.5 ug/mL
Compound 4: the middle estimate sits 8.3-fold (0.92 log units) below what was measured; measured number above the stated range.
By their numbers in this assay, from the lowest: compounds 1, 2 and 3 (each within the scatter of the next); then compound 4.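

In this assay, this aromatic carbon between two ring nitrogen atoms proves sensitive to its group: methyl and cyclopropyl stayed within the scatter of each other, whereas phenyl gives a 10-fold higher number from compound 3 to compound 4 (1.00 log units; beyond the scatter) and a 20-fold higher number from compound 1 to compound 4 (1.30 log units; beyond the scatter) at this place. For the compounds shown here, the tolerance seen with cyclopropyl therefore does not extend to phenyl, which the earlier steps did not reveal. Nothing at hand accounts for this change.

Open, on these data alone, is how cyclohexyl, a saturated six-membered ring, would read in this assay at this carbon. That comparison would separate ring size from aromatic character, and a phenyl bearing an amine would show whether substitution alters the step.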